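This account rests on a few compounds, and the source may have more. Where it says the series, first, only, none or still open, it means among the compounds named here.

Compound 1 `C[Se]/C(=N\C(=O)c1cccs1)NC(=O)c1cccs1` gives 9260 nM in an ADME assay on MCF-10A cells (Homo sapiens) for cytotoxicity, read by MTT assay, with a stated time of 72 h (on this read-out higher numbers stand for weaker inhibition of growth and lower numbers for stronger inhibition of growth), and compound 2 `O=C(/N=C(/NC(=O)c1cccs1)[Se]Cc1ccccc1)c1cccs1` gives 72500 nM; the step of a 7.8-fold higher number from compound 1 to compound 2 (0.89 log units; beyond the scatter) leaves compound 2 with the highest of the two numbers shown. Compound 3 `CS/C(=N\C(=O)c1cccs1)NC(=O)c1cccs1` differs from compound 2 by a group of 2 heavy atoms (1 carbon, 1 sulfur; no ring) in place of a group of 8 heavy atoms (7 carbon, 1 selenium; one six-membered aromatic ring of carbon only), on a carbon with a double bond to nitrogen. Among the measured compounds shown here, the only measured step that bears on this is a 7.8-fold higher number from compound 1 to compound 2 (0.89 log units; beyond the scatter), which the move to compound 3 reverses, while the swap of selenium for sulfur has no measured counterpart here. A drop toward the number of compound 1 is therefore expected for compound 3, about a 7.3-fold lower number from compound 2 to compound 3 (0.86 log units; beyond the scatter). The estimate for compound 3 is 10000 nM, within 3000 nM to 30000 nM.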

Compound 3, concentration for 50% growth inhibition: 19700 nM
Compound 3: the middle estimate sits 2.0-fold (0.29 log units) below what was measured, within the range that was stated.
By their numbers in this assay, from the lowest: compound 1; then compound 3; then compound 2.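

In this assay, methylsulfanyl in place of the group of 8 heavy atoms on the carbon with a double bond to nitrogen gives a 3.7-fold lower number from compound 2 to compound 3 (0.57 log units; beyond the scatter) and so lowers the number without reaching compound 1. With the methyl kept, sulfur in place of selenium alone gives a 2.1-fold higher number from compound 1 to compound 3 (0.33 log units; beyond the scatter) and so the atom itself changes the number, if modestly. No measurement at hand explains either step.

Going by these compounds, whether phenyl on the chain carbon raises the number as much on sulfur as on selenium remains open. So does the outcome for a longer chain, such as propyl, or a chain ending in an amine.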